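Compound 3 to compound 4: vinyl for prop-1-en-1-yl

A few compounds are considered here, and "the series" means these few. Any claim that something is new, unique, unknown or untested is made for them only; others in the source may bear on it.

Measured in a functional assay on Rec1 cells (Homo sapiens) for inhibition, read by luminescence and CellTiter-Glo, with a stated time of 72 h; a higher number here means a weaker inhibitor, a lower number a stronger inhibitor:
- compound 1 `O=C(CCl)N1CCCC(n2nc(-c3ccc(Oc4ccccc4)cc3)cc2CO)C1`: 400 nM
- compound 2 `C=CC(=O)N1CCCC(n2nc(-c3ccc(Oc4ccccc4)cc3)cc2C(=O)OCC)C1`: 13800 nM
- compound 3 `C/C=C/C(=O)N1CCCC(n2nc(-c3ccc(Oc4ccccc4)cc3)cc2CO)C1`: 27200 nM

Compound 3 stands at the high end of these numbers, within the scatter of compound 2 and far from compound 1. Compound 4 `C=CC(=O)N1CCCC(n2nc(-c3ccc(Oc4ccccc4)cc3)cc2CO)C1` carries vinyl in place of prop-1-en-1-yl on a carbonyl carbon. Going by the values given here, the only measured step at this place is a 68-fold higher number from compound 1 to compound 3 (1.83 log units; beyond the scatter), large and beyond the scatter, so a change here can count heavily in this assay. Compound 2 also carries vinylcarbonyl but differs elsewhere, and compound 2 gives 13800 nM, which argues against a full return to the level of compound 1. A moderate fall in the number is therefore expected, with wide uncertainty. The expected size is a 6.8-fold lower number from compound 3 to compound 4 (0.83 log units; beyond the scatter). Compound 4 is estimated at 4000 nM, with an expected range of 600 nM to 20000 nM.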

Compound 4, half-maximal inhibitory concentration: 5400 nM
Compound 4: the middle estimate sits 1.4-fold (0.13 log units) below what was measured; the range from low to high includes it.
By their numbers in this assay, from the lowest: compound 1; then compound 4; then compounds 2 and 3 (each within the scatter of the next).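

On the carbonyl carbon, vinyl in place of prop-1-en-1-yl gives a 5.0-fold lower number from compound 3 to compound 4 (0.70 log units; beyond the scatter) in this assay and so separates the two alkene-bearing groups, while chloromethyl keeps a clear lead over vinyl, with a 14-fold higher number from compound 1 to compound 4 (1.13 log units; beyond the scatter) on going the other way. The other site also counts: hydroxymethyl in place of ethoxycarbonyl on an aromatic carbon gives a 2.6-fold lower number from compound 2 to compound 4 (0.41 log units; beyond the scatter) with vinyl held fixed. Nothing available bears on the cause of these steps. Still open, as far as these compounds go, is how bromomethyl or ethynyl would read on the carbonyl carbon, and whether a carboxylic acid in place of hydroxymethyl would track ethoxycarbonyl.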